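Acetyl in place of methylsulfonyl in compound 3

The source may report more compounds than this note shows. Statements on the series, on what has been measured and on what is new or still open speak of the compounds shown alone.

In a physicochemical assay for solubility, measured as thermodynamic solubility, at pH 7.4 (a lower number here means a less soluble compound, a higher number a more soluble compound), compound 3 `CS(=O)(=O)N1CCOc2cc(COc3ccccc3)cnc21` gives 10000 nM. Compound 1 `O=C1CCOc2cc(OCc3ccc(F)cc3)ccc21` gives 5000 nM, within the scatter of compound 3. Compound 2 `COC(=O)N1CCOc2cc(COc3ccccc3)cnc21` reports only a limit, > 520000 nM. The remaining numeric comparison therefore places compound 3 level with compound 1, while the limit of compound 2 cannot be ranked as a number.

The next compound is compound 4 `CC(=O)N1CCOc2cc(COc3ccccc3)cnc21`, with acetyl in place of methylsulfonyl on a nitrogen on an aromatic ring in a ring.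

Among the measured compounds shown here, one measured step bears on this change, at the same nitrogen: an at least 52-fold lower number from compound 2 to compound 3 (1.71 log units; beyond the scatter). That step is large and is itself only a bound: the limit of > 520000 nM in this assay, at which 1 of the 3 values shown sits. For the measured compounds named here, compound 1 is joined to the others by no single-place step and adds nothing here.

Acetyl shares with the methoxycarbonyl of compound 2 a carbonyl on that nitrogen, so a large part of the step seen with compound 2 is expected to return, towards a higher number. Going by the values given here, it is a different group, however, and only one step supports this, so the range stays wide. The expected change is a 10-fold higher number from compound 3 to compound 4 (1.00 log units; beyond the scatter), beyond the scatter. For compound 4 the estimated value is 100000 nM, with an expected range from 20000 nM to 500000 nM.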

Compound 4, solubility: 40000 nM
Estimate against measurement, compound 4: 2.5-fold (0.40 log units) above; low and high end bracket the measured number.
By their numbers in this assay, from the lowest: compounds 1 and 3 (each within the scatter of the next); then compound 4. At a limit, above all of these: compound 2.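

Among the compounds shown here, at the nitrogen on the aromatic ring, this assay now gives a 4.0-fold higher number from compound 3 to compound 4 (0.60 log units; beyond the scatter), the first step at this position with a measured number at both ends. Methyl in place of methoxy on a carbonyl carbon gives an at least 13-fold lower number from compound 2 to compound 4 (1.11 log units; beyond the scatter), so acetyl and methoxycarbonyl do not read alike at this nitrogen, even though both place a carbonyl there, and the three groups now fall in the order methylsulfonyl, acetyl, methoxycarbonyl from the lowest number, with each step beyond the scatter. Compound 2 stands at a limit and not at a number, so its place at the top of that order is known only as a bound, and the step to it gives no true size: the limit of > 520000 nM in this assay, at which 1 of the 4 values shown sits.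

On these data alone, how far methoxycarbonyl really lies from acetyl stays open, and so does the reading for a longer chain on the carbonyl, such as propionyl, or for a dimethylamino group on it in place of methyl. As far as these compounds go, whether the same order holds with a different group on this nitrogen, such as a plain ethyl with no carbonyl or sulfonyl, also stays open.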